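Reversing the amide on two indole cores

The source may report more compounds than this note shows. Statements on the series, on what has been measured and on what is new or still open speak of the compounds shown alone.

The series joins one sulfonyl-amide half to two cores that each carry a cyclopentylmethyl-bearing group. Compound 1 `COc1cc(C(=O)NS(=O)(=O)c2ccccc2C)ccc1Cc1cn(C)c2ccc(C(=O)NCC3CCCC3)cc12` is the carbamoyl member on the first core, and in a functional assay on the whole organism with Cavia porcellus as the target (on this read-out lower numbers stand for an effect already at smaller amounts and higher numbers for an effect only at larger amounts of compound), compound 1 gives 19.2 umol/kg. Compound 2 `COc1cc(C(=O)NS(=O)(=O)c2ccccc2C)ccc1Cn1cc(C)c2ccc(C(=O)NCC3CCCC3)cc21` has the second core, and the difference between the two cores is not broken down here. In this assay compound 2 gives about 30 umol/kg, which lies within the scatter of compound 1, so no order between them is claimed. Compound 3 `COc1cc(C(=O)NS(=O)(=O)c2ccccc2C)ccc1Cc1cn(C)c2ccc(NC(=O)CC3CCCC3)cc12` differs from compound 1 by ((cyclopentylmethyl)carbonyl)amino in place of (cyclopentylmethyl)carbamoyl on an aromatic carbon. In this assay compound 3 gives 0.41 umol/kg, and the step is a 47-fold lower number from compound 1 to compound 3 (1.67 log units; beyond the scatter).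

Compound 4 `COc1cc(C(=O)NS(=O)(=O)c2ccccc2C)ccc1Cn1cc(C)c2ccc(NC(=O)CC3CCCC3)cc21` differs from compound 2 by ((cyclopentylmethyl)carbonyl)amino in place of (cyclopentylmethyl)carbamoyl on an aromatic carbon, the same change at the same place, now on the second core. Among the measured compounds shown here, only one example of this change is measured. The step from compound 2 to compound 4 in this assay is expected to be of similar size, a 46-fold lower number from compound 2 to compound 4 (1.66 log units; beyond the scatter), because the single measured case was a 47-fold lower number from compound 1 to compound 3 (1.67 log units; beyond the scatter). The estimate for compound 4 is accordingly 0.65 umol/kg, between 0.2 umol/kg and 2.5 umol/kg.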

Compound 4, dose for half-maximal effect: 0.3 umol/kg
Beside the measured number, compound 4's estimate is 2.2-fold (0.34 log units) above it; the range from low to high includes it.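

In this assay, ((cyclopentylmethyl)carbonyl)amino in place of (cyclopentylmethyl)carbamoyl gives a 100-fold lower number from compound 2 to compound 4 (2.00 log units; beyond the scatter), so the large step seen on the core of compound 1 recurs on the core of compound 2. The two steps run the same way and do not differ in size beyond the scatter: the same change on two cores in this assay, a 47-fold lower number (1.67 log units; beyond the scatter) from compound 1 to compound 3 and a 100-fold lower number (2.00 log units; beyond the scatter) from compound 2 to compound 4, 2.1-fold (0.33 log units) apart, within the scatter of two such steps.

Among the compounds shown here, this shows that the change carries across these two cores with this cyclopentylmethyl-bearing group, but with only two pairs it does not show that it would carry to any other core or group, nor why the change lowers the number.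

Still open, as far as these compounds go, is how much the cyclopentyl ring itself contributes on the reversed amide, which a cyclohexyl ring or an open-chain butyl group could test. Also open, from the compounds shown here alone, is whether the amide link is the only one that gives such low numbers, or whether a urea or a carbamate in its place would do the same on either core.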